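Extending the Chain Amide on the Shared Core

This account rests on a few compounds, and the source may have more. Where it says the series, first, only, none or still open, it means among the compounds named here.

Measured compounds:
- compound 1, `CCSCCc1c[nH]c2ccc(F)cc12`: > 100 nM (a limit of the assay, not a number)
- compound 2, `N#CSCCCc1c[nH]c2ccc(F)cc12`: 23 nM
- compound 3, `NC(=O)CCc1c[nH]c2ccc(F)cc12`: 34 nM

In an assay on isolated protein for inhibition of Myeloperoxidase (Homo sapiens), read by ELISA, with a stated time of 5 min (on this read-out lower numbers stand for stronger inhibition and higher numbers for weaker inhibition), compound 3 holds the highest of the two numbers shown; compound 2 sits nearest, with a 1.5-fold higher number from compound 2 to compound 3 (0.17 log units; within the scatter). Compound 1 is known only as a limit (the limit of > 100 nM in this assay, at which 1 of the 3 values shown sits). Compound 4, `CNC(=O)CCCc1c[nH]c2ccc(F)cc12`, differs from compound 3 by (methylcarbamoyl)methyl in place of carbamoyl on a saturated chain carbon, two bonds along the chain from an aromatic carbon. The step of an at least 2.9-fold lower number from compound 1 to compound 3 (0.46 log units; beyond the scatter) shows that the carbamoyl group improves on ethylsulfanyl, while a 1.5-fold higher number from compound 2 to compound 3 (0.17 log units; within the scatter) shows a longer neutral chain group and carbamoyl giving numbers within the scatter. The change to (methylcarbamoyl)methyl is therefore expected to give a step of about a 1.1-fold lower number from compound 3 to compound 4 (0.05 log units; within the scatter), that is none beyond the scatter. Compound 4 is estimated at 30 nM, between 10 nM and 90 nM.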

Compound 4, half-maximal inhibitory concentration: 95 nM
Estimate against measurement, compound 4: 3.2-fold (0.50 log units) below; measured number outside the range, above it.
By their numbers in this assay, from the lowest: compounds 2 and 3 (each within the scatter of the next); then compound 4. At a limit, above all of these: compound 1.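

In this assay, the modest step of a 2.8-fold higher number from compound 3 to compound 4 (0.45 log units; beyond the scatter) shows that this position does not accept every change to the amide, since (methylcarbamoyl)methyl gives weaker inhibition than carbamoyl. On the same chain, the step of a 4.1-fold higher number from compound 2 to compound 4 (0.62 log units; beyond the scatter) shows that the end group matters too, which the pair of compounds 2 and 3, within the scatter of each other, did not reveal. The step of an at least 1.0-fold lower number from compound 1 to compound 4 (0.02 log units; that floor lies within the scatter) cannot be read as a difference. Compound 1 is known only as a limit: the limit of > 100 nM in this assay, at which 1 of the 4 values shown sits.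

The compounds shown leave open whether the longer chain or the methyl on the amide nitrogen accounts for the loss. Neither a plain carbamoyl on the longer chain nor a carboxylic acid at its end is among them.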